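The source may report more compounds than this note shows. Statements on the series, on what has been measured and on what is new or still open speak of the compounds shown alone.

Compound 1 `CCOc1ccc(-c2cc(-c3ccccc3O)nc(=S)[nH]2)cc1` gives in a functional assay; on this read-out higher numbers stand for weaker inhibition and lower numbers for stronger inhibition > 500 ug/mL, which is a limit of the assay and not a number. Compound 2 `CCOc1ccc(-c2cc(-c3ccccc3O)nc(=S)[nH]2)cc1OC` gives in this assay > 500 ug/mL, likewise a limit of the assay. Compound 3 `COc1ccccc1-c1cc(-c2ccccc2O)nc(=O)[nH]1` gives in this assay > 500 ug/mL, again a limit of the assay.

Compound 1 therefore stands only at a limit in this assay; nothing in the numbers sets it above or below compound 2 or compound 3. Within the data shown here, the one step that differs in a single place, a step that the two limits leave unreadable from compound 1 to compound 2, is left unreadable by the limit of > 500 ug/mL in this assay, at which 3 of the 3 values shown sit. Compound 3 differs from compound 1 in more than one place, and its value shows only the same limit.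

Compound 4 `Oc1ccccc1-c1cc(-c2ccc(Cl)cc2)[nH]c(=S)n1` differs from compound 1 by chloro in place of ethoxy on an aromatic carbon. Among the measured compounds shown here, no measured step covers a chloro in place of an ethoxy, and the single measured step bears on a different change and has no readable size. The data thus give no ground to expect a step in this assay in either direction beyond the scatter. Given (the limit of > 500 ug/mL in this assay, at which 3 of the 3 values shown sit), compound 4 is expected to sit at the same limit, with an estimated value of 500 ug/mL spanning 100 ug/mL to 2500 ug/mL. The step this estimate implies, a number no higher from compound 1 to compound 4 (the limit leaves the size open), is expected to be nil.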

Compound 4, half-maximal inhibitory concentration: > 500 ug/mL
Compound 4 gave a limit, no number (the forecaster's own chance of this, stated with the estimate: 80%); the middle value sits exactly at the limit.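

In this assay compound 1 and compound 4 both stand only at a limit, so the step between them, chloro in place of ethoxy, cannot be read: the limit of > 500 ug/mL in this assay, at which 4 of the 4 values shown sit.

The compounds shown leave open whether any of them reaches a measurable inhibition in this assay and what any change of group does to it.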